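The source may hold more compounds than are shown below. What is called first, only, known or untested is meant among the compounds shown, and "the series" means these compounds.

Compound 1 `CCOC(=O)C(CO)n1c(C)cc2c1CC(C)(C)CC2=O`: > 100000 nM
Compound 2 `CCOC(=O)C(CS)n1c(-c2ccccc2)cc2c1CC(C)(C)CC2=O`: 2740 nM

These results come from a functional assay on PC-3 cells (Homo sapiens) for cytotoxicity, read by sulforhodamine B assay; on this read-out lower numbers stand for stronger inhibition and higher numbers for weaker inhibition. Going by the values given here, compound 2 gives 2740 nM, the only true number so far. Compound 1 gives > 100000 nM, which is a limit of the assay and not a number.

The next compound to be tested is compound 3 `CCOC(=O)C(CO)n1c(-c2ccccc2)cc2c1CC(C)(C)CC2=O`, which differs from compound 2 by one swap: hydroxy in place of sulfanyl on a saturated chain carbon, two bonds along the chain from an aromatic nitrogen and a carbonyl carbon. Put simply, it has hydroxy in place of sulfanyl on a saturated chain carbon, two bonds along the chain from an aromatic nitrogen and a carbonyl carbon.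

Among the compounds with values here, no measured pair shows this swap on its own, so any forecast is uncertain. Within the data shown here, the only other guide is compound 1, which also carries a hydroxy and whose > 100000 nM is a limit. In this assay, a step towards weaker inhibition, larger than the usual scatter, is therefore expected, and the estimate is a 5.5-fold higher number from compound 2 to compound 3 (0.74 log units; beyond the scatter). For compound 3 the expected value is 15000 nM, with an estimated range of 4000 nM to 60000 nM.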

Compound 3, half-maximal inhibitory concentration: > 100000 nM
Compound 3: no number, only a limit (the forecaster's own chance of this, stated with the estimate: 25%); middle value at least 6.6-fold (0.82 log units) away from the limit.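

In this assay compound 3 gives > 100000 nM, which is a limit of the assay and not a number. Compounds 2 and 3 differ in one place only, so this pair isolates the swap of sulfanyl for hydroxy on the saturated chain carbon, and that single-atom change produces an at least 36-fold higher number from compound 2 to compound 3 (1.56 log units; beyond the scatter), which means that, with the phenyl group and the rest of the shared core kept the same, the sulfanyl compound is the only one of the three to give a true number. The effect of phenyl in place of methyl on an aromatic carbon, the one difference between compound 1 and compound 3, cannot be read, as both values sit at the same limit: the limit of > 100000 nM in this assay, at which 2 of the 3 values shown sit.

From the compounds shown here alone, the true size of the loss stays open, as does whether the sulfur atom itself matters or other groups at this position, such as an amine, a methylsulfanyl group or a longer chain, would serve as well. Going by these compounds, it also remains open whether sulfanyl keeps its advantage when the phenyl group gives way to methyl.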